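The source may hold more compounds than are shown below. What is called first, only, known or untested is meant among the compounds shown, and "the series" means these compounds.

Notes on the series. Among the compounds with values here, in an ADME assay for permeability, using PAMPA, with a stated time of 30 min, at pH 7.4 (a higher number here means that the compound crosses the layer faster, a lower number that the compound crosses the layer more slowly), compound 1 `FC(F)(F)c1ccc(-c2ccc3c(NCCCNCc4ccco4)ccnc3c2)cc1` gives 237 10^-6 cm/s, the second highest of the three numbers so far. Compound 2 `COc1cccc(Oc2ccc3c(NCCCNCc4cc(F)ccc4OC)ccnc3c2)c1` gives 317 10^-6 cm/s in this assay, a reading that sits within the scatter of compound 1, so the two cannot be told apart. Compound 3 `COc1cccc(CNCCCNc2ccnc3cc(CCC(C)C)ccc23)c1O` gives 23 10^-6 cm/s in this assay, and that gap to compound 1 lies beyond the scatter. Within the data shown here, no pair among the measured compounds differs in one place only, so no single step is on record.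

The next compound, compound 4 `CCC(CC)c1ccc2c(NCCCNCc3ccco3)ccnc2c1`, takes the step from compound 1 in one place: pentan-3-yl in place of 4-(trifluoromethyl)phenyl on an aromatic carbon The shared core and the rest of the chain with the furan-2-ylmethyl end stay as in compound 1. Among the measured compounds shown here, no measured pair isolates this kind of change, and compound 3, which carries a chain rather than a ring on its core yet differs from compound 1 in other places as well, is the only point of reference.

Expectation: compound 4 is estimated at 150 10^-6 cm/s, with a range of 50 10^-6 cm/s to 350 10^-6 cm/s. The step that this estimate means, a 1.6-fold lower number from compound 1 to compound 4 (0.20 log units; within the scatter), is expected to be downward but of modest size, likely close to the scatter rather than clearly beyond it.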

Compound 4, apparent permeability: 23 10^-6 cm/s
Compound 4: the middle estimate sits 6.5-fold (0.81 log units) above what was measured; the measured number lies below the stated range.
By their numbers in this assay, from the lowest: compounds 3 and 4 (each within the scatter of the next); then compounds 1 and 2 (each within the scatter of the next).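

In this assay, within the data shown here, pentan-3-yl in place of 4-(trifluoromethyl)phenyl on this aromatic carbon gives a 10-fold lower number from compound 1 to compound 4 (1.01 log units; beyond the scatter), the first single-place step on record for the series. This shows that, with the furan-2-ylmethyl end and the shared core held as they are, the group at this position can carry a large step in this read-out. The two groups agree in having no hydrogen-bond donors or acceptors and no net charge, but differ in the aromatic ring, in size and in the fluorine, and nothing at hand separates these differences or gives a reason for the step.

From the compounds shown here alone, whether a plain phenyl ring without the trifluoromethyl, a saturated ring such as cyclohexyl or a straight pentyl chain at this position would read with compound 1 or with compound 4 stays open. Going by these compounds, the finding also rests on one pair, so it remains open whether the same change gives a step of this size when the furan-2-ylmethyl end is replaced by a substituted benzyl group.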